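Replacing methylsulfonyl with methoxy on an aromatic carbon

This account rests on a few compounds, and the source may have more. Where it says the series, first, only, none or still open, it means among the compounds named here.

In a functional assay on MCF7 cells (Homo sapiens) for cytotoxicity, read by CellTiter-Glo, with a stated time of 5 days (a higher number here means a weaker inhibitor, a lower number a stronger inhibitor), compound 1 `CC/C(=C(/c1ccc(/C=C/C(=O)O)cc1)c1ccc2[nH]ncc2c1)c1ccccc1` gives 6 nM, while compound 2 `CC/C(=C(/c1ccc(/C=C/C(=O)O)cc1)c1ccc2[nH]ncc2c1)c1ccccc1S(C)(=O)=O` gives 70 nM, the higher of the two numbers and so the weaker inhibitor. The next structure is compound 3 `CC/C(=C(/c1ccc(/C=C/C(=O)O)cc1)c1ccc2[nH]ncc2c1)c1ccccc1OC`, in which methoxy takes the place of methylsulfonyl on an aromatic carbon, ortho to a large group: methoxy in place of methylsulfonyl on an aromatic carbon. Going by the values given here, only one measured step bears on this change. Putting methylsulfonyl in place of hydrogen on that carbon gave a 12-fold higher number from compound 1 to compound 2 (1.07 log units; beyond the scatter), a large step beyond the scatter. Among the compounds with values here, removing methylsulfonyl may therefore win back part of that loss, but methoxy is not hydrogen, and no measurement yet shows how the two compare. In this assay, a drop beyond the scatter is expected, an estimated 4.7-fold lower number from compound 2 to compound 3 (0.67 log units; beyond the scatter). Compound 3 is estimated at 15 nM, with an expected range of 5 nM to 50 nM.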

Compound 3, half-maximal inhibitory concentration: 25 nM
The estimate for compound 3 lay 1.7-fold (0.22 log units) below the measured number, within the range that was stated.
By their numbers in this assay, from the lowest: compound 1; then compound 3; then compound 2.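

In this assay, methoxy recovers part of what methylsulfonyl lost on this carbon, with a 2.8-fold lower number from compound 2 to compound 3 (0.45 log units; beyond the scatter) and yet still a 4.2-fold higher number from compound 1 to compound 3 (0.62 log units; beyond the scatter) when set against plain hydrogen. The loss at this position therefore depends on which group is placed there, rather than being the same for any group that replaces hydrogen, and among the three compounds shown, hydrogen gives the lowest number. Nothing measured here explains why methoxy costs less than methylsulfonyl.

Still open, going by these compounds, is whether a fluorine or a chlorine on this carbon would bring the number back to that of compound 1, or whether a longer chain such as ethoxy would raise it further. Also open, on these data alone, is whether methoxy would give a similar result on the other carbons of this ring.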